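Compound 3 Stands Alone, Compound 4 Awaits Its Number

The source may hold more compounds than are shown below. What is called first, only, known or untested is meant among the compounds shown, and "the series" means these compounds.

Results in a functional assay on A-375 cells (Homo sapiens) for antiproliferative activity, read by CCK-8 assay, with a stated time of 72 h; on this read-out higher numbers stand for weaker inhibition and lower numbers for stronger inhibition:
Compound 1 `CCc1ccc(SCc2ccc(/C=C/C(=O)Nc3ccccc3N)cc2)cc1` gives "not determined" (no result reported)
Compound 2 `Nc1ccccc1NC(=O)/C=C/c1ccc(CSc2cccc3ccccc23)cc1` gives "not determined" (no result reported)
Compound 3 `Nc1ccccc1NC(=O)/C=C/c1ccc(CSCCc2ccccc2)cc1` gives 15700 nM

Among the measured compounds shown here, compound 3 holds the only number in this set (15700 nM) and so cannot be ranked against compound 1 or compound 2, which have no reported result. Compound 4 `CC(C)(C)c1ccc(SCc2ccc(/C=C/C(=O)Nc3ccccc3N)cc2)cc1` has not yet been measured. It differs from compound 3 by one change (4-(tert-butyl)phenyl in place of phenethyl on a sulfur): 4-(tert-butyl)phenyl in place of phenethyl on a sulfur. For the measured compounds named here, no measured pair shows what such a change does. Only a small expected step (a 1.7-fold lower number from compound 3 to compound 4 (0.24 log units; within the scatter)) toward stronger inhibition is therefore proposed, no larger than the usual scatter. Compound 4 is expected to read 9000 nM in this assay, with an estimated range from 2500 nM to 25000 nM once tested.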

Compound 4, half-maximal inhibitory concentration: 1550 nM
The estimate for compound 4 lay 5.8-fold (0.76 log units) above the measured number; the whole stated range lies above it.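

In this assay, 4-(tert-butyl)phenyl in place of phenethyl on the sulfur brings a 10-fold lower number from compound 3 to compound 4 (1.01 log units; beyond the scatter), the first measured sign that the group on this sulfur can move the read-out. Both groups hold one six-membered aromatic ring of carbon only and count no hydrogen-bond donors or acceptors, so the step comes without a change in those counts. Nothing on hand explains the step. The compounds shown leave open whether the tert-butyl group or the loss of the phenethyl chain carries it. Going by these compounds, how an amine or a carboxylic acid in place of the tert-butyl group would read also remains open.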